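Swapping a Carbamate Chain for a Dimethylamide Chain

The source may report more compounds than this note shows. Statements on the series, on what has been measured and on what is new or still open speak of the compounds shown alone.

Of the compounds shown here, two sharing one core have been measured so far. Compound 1 `CC1=C(N2CC2)C(=O)C(CC(C)OC(N)=O)=C(N2CC2)C1=O` gives 5.86 in a functional assay on L1210 cells (Mus musculus), with a stated time of 1 days; on this read-out higher numbers stand for higher potency (the scale is a negative logarithm) and lower numbers for lower potency. Compound 2 `CC1=C(N2CC2)C(=O)C(C(C)COC(N)=O)=C(N2CC2)C1=O` gives 5.93 in this assay. Compound 2 stands highest of the two numbers, but its nearest neighbour is compound 1, and the step of a number 0.07 log units higher from compound 1 to compound 2 (within the scatter) sits within the scatter, so the two cannot be told apart.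

Compound 3 `CC1=C(N2CC2)C(=O)C(CCC(=O)N(C)C)=C(N2CC2)C1=O` has not yet been measured. Its change from compound 2 is a group of 7 heavy atoms (5 carbon, 1 nitrogen, 1 oxygen; no ring) in place of a group of 7 heavy atoms (4 carbon, 1 nitrogen, 2 oxygen; no ring), on a double-bonded ring carbon. Among the measured compounds shown here, the only measured step, from compound 1 to compound 2, moved a group of the same seven heavy atoms into a different arrangement and left the reading essentially unchanged. For the measured compounds named here, no measured step covers an exchange of the carbamate for a dimethylcarbamoyl group, so the data give no direction for this change. The expectation is therefore a step near zero, a number 0.13 log units lower from compound 2 to compound 3 (within the scatter), with wide uncertainty. The estimate for compound 3 in this assay is 5.8, within a range from 5.3 to 6.3.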

Compound 3, logarithm of the reciprocal of the active concentration, log(1/C): 5.09
Estimate against measurement, compound 3: 0.71 log units above; the measured number lies below the stated range.
By their numbers in this assay, from the lowest: compound 3; then compounds 1 and 2 (each within the scatter of the next).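

This position on the shared core responds to what the chain carries: in this assay, the 2-(dimethylcarbamoyl)ethyl chain gives a number 0.84 log units lower from compound 2 to compound 3 (beyond the scatter) and, set against the other carbamate chain, a number 0.77 log units lower from compound 1 to compound 3 (beyond the scatter) on the same read-out. The two carbamate chains could not be told apart, so this exchange is the first change shown that goes beyond the scatter, even though the chain still has 7 heavy atoms, while the count moves from 1 hydrogen-bond donor and 2 hydrogen-bond acceptors to 0 donors and 1 acceptor. Nothing available explains which part of the exchange accounts for the lower number.

The compounds shown leave open which difference matters, as compound 3 loses the carbamate oxygen and gains the two methyl groups on nitrogen in one step: a chain ending in an unsubstituted primary amide, or one ending in an N,N-dimethylcarbamate, would separate the two. Going by these compounds, how a carboxylic acid, an amine or a longer chain at this position would read in this assay also stays open.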